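From 2-Bromophenyl to 2-Chloro-6-Fluorophenyl on Compound 2

This account rests on a few compounds, and the source may have more. Where it says the series, first, only, none or still open, it means among the compounds named here.

In a functional assay on HL-60 cells (Homo sapiens) for inhibition, read by MTT assay, with a stated time of 48 h, tested at 10 uM (on this read-out lower numbers stand for less inhibition of growth and higher numbers for more inhibition of growth at the one concentration tested), compound 1 `Cc1cc(=O)c2c(O)c(CN3CCN(C(=O)OC(C)(C)C)CC3)c(O)c([C@H]3CCN(C)C[C@H]3O)c2o1` reaches 13% and compound 2 `Cc1oc2c([C@H]3CCN(C)C[C@H]3O)c(O)cc(O)c2c(=O)c1C(O)c1ccccc1Br` reaches 52% as the higher of the two numbers, a gap beyond the usual scatter of such measurements. Compound 3 `Cc1oc2c([C@H]3CCN(C)C[C@H]3O)c(O)cc(O)c2c(=O)c1C(O)c1c(F)cccc1Cl` has not been measured yet. It differs from compound 2 by a single change: 2-chloro-6-fluorophenyl in place of 2-bromophenyl on a saturated chain carbon bound to an aromatic carbon and an oxygen on a saturated carbon. For the measured compounds named here, no measured pair shows what such a swap does, so the best guide is compound 2 at 52% and no step beyond the scatter is expected in this assay for this change. The estimated change is a number 4 percentage points lower from compound 2 to compound 3 (within the scatter) and stays within the scatter. The expected value for compound 3 is 48% (range 28% to 68%).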

Compound 3, percent growth inhibition at one concentration: 49%
Compound 3: middle estimate off by 1 percentage points, on the low side; the measured number falls inside the stated range.
By their numbers in this assay, from the lowest: compound 1; then compounds 3 and 2 (each within the scatter of the next).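

In this assay, replacing 2-bromophenyl with 2-chloro-6-fluorophenyl on the saturated chain carbon gives a number 3 percentage points lower from compound 2 to compound 3 (within the scatter). For the compounds shown here, this is the first comparison at this position that changes only one place, and it shows that a ring carrying bromine and a ring carrying chlorine and fluorine cannot be told apart on this read-out. Nothing available explains why the two rings give such similar results.

From the compounds shown here alone, it remains open what a plain phenyl, a pyridine ring or an aminophenyl group would do on this carbon, so the need for any halogen at all is unsettled. The role of the neighbouring hydroxy group is also unresolved, and a ketone or a simple methylene in the (hydroxy)methyl unit would test it.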